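The source may report more compounds than this note shows. Statements on the series, on what has been measured and on what is new or still open speak of the compounds shown alone.

Measured so far:
- compound 1 `CCOC(=O)c1ccc(NC(=O)NCc2ccnnc2)cc1`, in an assay on isolated protein for activation of Nicotinamide phosphoribosyltransferase (Homo sapiens) (on this read-out higher numbers stand for an effect only at larger amounts of compound and lower numbers for an effect already at smaller amounts), compound 1 gives > 100000 nM
- compound 2 `CCN(C1CCCC1)S(=O)(=O)c1ccc(NC(=O)NCc2ccncc2)cc1`, in this assay compound 2 gives 60 nM
- compound 3 `O=C(NCc1cn[nH]c1)Nc1ccc(S(=O)(=O)c2ccc(Cl)cc2)cc1`, in this assay compound 3 gives 23 nM

Compound 1 sits at the limit of > 100000 nM in this assay, at which 1 of the 3 values shown sits, which is a limit of the assay and not a number. Among the two real numbers compound 2 stands highest; the nearest, compound 3, lies lower by more than the usual scatter. Within the data shown here, no pair of measured compounds differs in only one place, so no measured step is available to calibrate a single change.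

Compound 4 `O=C(NCc1ccncc1)Nc1ccc(S(=O)(=O)c2ccccc2Cl)cc1` is not yet measured. It is derived from compound 2 by 2-chlorophenyl in place of cyclopentyl(ethyl)amino on a sulfonyl sulfur. Compound 3, with 23 nM, shows that the cyclopentyl(ethyl)amino group is not needed on this core for a low number, though its other part also differs from compound 2, so it cannot be read as a step. The change from compound 2 to compound 4 is expected to give at most a small lowering, likely within the usual scatter, a 1.5-fold lower number from compound 2 to compound 4 (0.18 log units; within the scatter). Compound 4 is therefore estimated at 40 nM, with a plausible range from 12 nM to 130 nM.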

Compound 4, half-maximal effective concentration: 79 nM
For compound 4 the middle estimate is 2.0-fold (0.30 log units) below the measured one; low and high end bracket the measured number.
By their numbers in this assay, from the lowest: compound 3; then compounds 2 and 4 (each within the scatter of the next). At a limit, above all of these: compound 1.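

In this assay, the series now has its first step between compounds that differ in one place (a 1.3-fold higher number from compound 2 to compound 4 (0.12 log units; within the scatter)). On a sulfonyl sulfur whose other neighbour is an aromatic carbon, 2-chlorophenyl and cyclopentyl(ethyl)amino therefore cannot be told apart on this read-out, although one group is an aromatic ring of carbon carrying chlorine and the other a non-aromatic ring of carbon joined through nitrogen. On the core shared by compounds 2 and 4, this single pair shows that a nitrogen attached to the sulfonyl sulfur is not required for a value in the range of compound 2, something compound 3 could only suggest, as it also differs in its other part.

Among these compounds, the single step leaves open how far this tolerance extends, for example to an unsubstituted phenyl, which would show whether the chlorine matters, or to a morpholine, a dimethylamino group or a carboxylic acid on the same sulfur. Nothing measured in this set gives a cause for the size of the step.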